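A few compounds are considered here, and "the series" means these few. Any claim that something is new, unique, unknown or untested is made for them only; others in the source may bear on it.

Measured so far:
compound 1, `COc1cc2ncnc(NCc3cccc(NC(=O)Nc4ccc(C)cc4)c3)c2cc1OC` — 34200 nM
compound 2, `COc1cc2ncnc(NCc3cccc(NC(=O)Nc4ccc(F)cc4)c3)c2cc1OC` — 42100 nM

In a functional assay on MGC-803 cells (Homo sapiens) for antiproliferative activity, read by MTT assay (on this read-out higher numbers stand for weaker inhibition and lower numbers for stronger inhibition), compound 1 gives 34200 nM, and compound 2 gives 42100 nM. Compound 2 thus stands next to compound 1 at a gap that lies within the scatter of this assay: a 1.2-fold higher number from compound 1 to compound 2 (0.09 log units; within the scatter). Both numbers are high, so both compounds inhibit the growth of these cells only weakly.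

Compound 3, `COc1cc2ncnc(NCc3cccc(NC(=O)Nc4ccc(Cl)cc4)c3)c2cc1OC`, is not yet measured. It differs from compound 2 in one place: chloro in place of fluoro on an aromatic carbon. Among the measured compounds shown here, the only measured step that bears on this change is the one from compound 1 to compound 2, where fluoro replaced methyl on the same aromatic carbon, and it did not move the number beyond the scatter. Swapping one small halogen for another at that position therefore gives little reason to expect a step beyond the scatter in this assay, in either direction. Compound 3 is accordingly estimated at 36000 nM, with a range from 15000 nM to 85000 nM, which corresponds to an expected step of a 1.2-fold lower number from compound 2 to compound 3 (0.07 log units; within the scatter).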

Compound 3, half-maximal inhibitory concentration: 44200 nM
Beside the measured number, compound 3's estimate is 1.2-fold (0.09 log units) below it, within the range that was stated.
By their numbers in this assay, from the lowest: compounds 1, 2 and 3 (each within the scatter of the next).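

In this assay, the step of a 1.0-fold higher number from compound 2 to compound 3 (0.02 log units; within the scatter) and the step of a 1.3-fold higher number from compound 1 to compound 3 (0.11 log units; within the scatter) both lie within the scatter, so chloro behaves here like fluoro and like methyl. Among the compounds shown here, the earlier pair offered only two groups on this aromatic carbon, para to a large group, whereas three groups now give numbers that cannot be told apart, all in the range of weak inhibition. This makes the finding a little broader, but it holds only for these three small groups on this one carbon, and nothing available explains why the three numbers sit so close together.

The compounds shown leave open whether this flat picture would last with a quite different group on the same carbon, such as an amine, a carboxylic acid or a longer chain like butyl. They also leave open whether any change at this place could give strong inhibition of these cells, or whether that would take a change elsewhere in the shared core.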